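Swapping the Amide Aryl Group: From Compound 2 to Compound 3

The source may report more compounds than this note shows. Statements on the series, on what has been measured and on what is new or still open speak of the compounds shown alone.

Two compounds share one core and differ only in the aryl group carried on the amide nitrogen. Compound 1 `NS(=O)(=O)c1ccc(NC(=O)c2cn(Cc3c(F)cccc3F)c3ccc(=O)[nH]c3c2=O)cc1` carries a sulfamoyl group on that ring; in an in vitro assay on Sf21 cells for inhibition of high affinity 3',5'-cyclic-AMP phosphodiesterase 7A (Homo sapiens), read by scintillation proximity assay, with a stated time of 30 min (on this read-out higher numbers stand for weaker inhibition and lower numbers for stronger inhibition), compound 1 gives 34 nM. Compound 2 `CSc1ccc(NC(=O)c2cn(Cc3c(F)cccc3F)c3ccc(=O)[nH]c3c2=O)cc1` carries a methylsulfanyl group instead, and in this assay compound 2 gives 86 nM. For the measured compounds named here, the step of a 2.5-fold higher number from compound 1 to compound 2 (0.40 log units; beyond the scatter) is the only measured comparison, so compound 2 stands as the higher of the two numbers, the weaker inhibitor.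

Compound 3 `COc1cc(NC(=O)c2cn(Cc3c(F)cccc3F)c3ccc(=O)[nH]c3c2=O)cc(OC)c1` changes the same region again: 3,5-dimethoxyphenyl in place of 4-(methylsulfanyl)phenyl on an amide-type nitrogen. Going by the values given here, no measured step shows what two methoxy groups on this ring do, and the one step that exists, a 2.5-fold higher number from compound 1 to compound 2 (0.40 log units; beyond the scatter), swaps a single group and does not cover the change at hand. It does show that a change in this part of the molecule has so far moved the number only modestly. Among the compounds with values here, with this as the only guide, the step to compound 3 is expected to be small, a 1.2-fold higher number from compound 2 to compound 3 (0.07 log units; within the scatter), with a wide range owing to the lack of direct evidence. The estimate for compound 3 in this assay is 100 nM, expected to fall between 30 nM and 350 nM.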

Compound 3, half-maximal inhibitory concentration: 212 nM
The estimate for compound 3 lay 2.1-fold (0.33 log units) below the measured number; low and high end bracket the measured number.
By their numbers in this assay, from the lowest: compound 1; then compound 2; then compound 3.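

With three aryl groups now compared on the amide nitrogen in this assay, the position proves sensitive to more than one kind of swap, since 3,5-dimethoxyphenyl gives the highest number of the set: a 2.5-fold higher number from compound 2 to compound 3 (0.39 log units; beyond the scatter) and a 6.2-fold higher number from compound 1 to compound 3 (0.79 log units; beyond the scatter). For the compounds shown here, the single step seen earlier could have been a one-off, but this second step, of similar size, takes the number further in the same direction, and the ranking now runs from 4-sulfamoylphenyl through 4-(methylsulfanyl)phenyl to 3,5-dimethoxyphenyl. Nothing available here explains why the number rises with this change.

This change replaces the group and also alters where the ring carries its substituents, so these three compounds cannot show how much of the rise comes from the methoxy groups themselves and how much from their placement. A phenyl ring carrying a single methoxy group would help to separate the two, and a ring carrying an amine or a carboxylic acid would show whether the sulfamoyl compound's lower number can be matched by other groups.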